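Swapping bromo for nitro on the shared aromatic ring

A few compounds are considered here, and "the series" means these few. Any claim that something is new, unique, unknown or untested is made for them only; others in the source may bear on it.

Compound 1 `COC(=O)C1=C(C)NC(=O)NC1c1ccc(Cl)cc1`: 34200 nM
Compound 2 `COC(=O)C1=C(C)NC(=O)NC1c1ccc(Br)cc1`: 64100 nM

Both compounds were tested in an assay for inhibition of beta-glucuronidase (Bos taurus), read by spectrophotometry, with a stated time of 30 min; on this read-out higher numbers stand for weaker inhibition and lower numbers for stronger inhibition. Compound 1 gives 34200 nM and compound 2 gives 64100 nM; the two numbers lie within the scatter of each other, with a 1.9-fold higher number from compound 1 to compound 2 (0.27 log units; within the scatter), so neither compound can be set apart from the other on these two values. Compound 3 `COC(=O)C1=C(C)NC(=O)NC1c1ccc([N+](=O)[O-])cc1` differs from compound 2 by nitro in place of bromo on an aromatic carbon. Going by the values given here, the only measured step that bears on this position is the halogen swap, a 1.9-fold higher number from compound 1 to compound 2 (0.27 log units; within the scatter), which stayed within the scatter; no step with a nitro group is available, so the change from bromo to nitro has no direct precedent here. On that thin basis compound 3 is expected to give a number close to that of compound 2 in this assay, with a 1.1-fold lower number from compound 2 to compound 3 (0.03 log units; within the scatter) as the estimated step. The estimate for compound 3 is 60000 nM, with a range from 20000 nM to 180000 nM.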

Compound 3, half-maximal inhibitory concentration: 49100 nM
Beside the measured number, compound 3's estimate is 1.2-fold (0.09 log units) above it; the range from low to high includes it.
By their numbers in this assay, from the lowest: compounds 1, 3 and 2 (each within the scatter of the next).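

The change from a lone halogen atom to nitro, a group of 3 heavy atoms with 2 hydrogen-bond acceptors, gave a 1.3-fold lower number from compound 2 to compound 3 (0.12 log units; within the scatter) in this assay and, set against chloro, a 1.4-fold higher number from compound 1 to compound 3 (0.16 log units; within the scatter) in the same assay. The earlier pair had compared only one halogen with another, whereas this result shows that a non-halogen group on this aromatic carbon, para to a large group, also stays within the scatter. On these values chloro, bromo and nitro cannot be told apart at this position.

The compounds shown leave open whether an amine, a carboxylic acid or a methoxy group at this position would also stay within the scatter of these three compounds. No supporting data are available to explain this result.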